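The source may report more compounds than this note shows. Statements on the series, on what has been measured and on what is new or still open speak of the compounds shown alone.

Series notes. Of the compounds shown here, three on one shared core have been measured in a functional assay on CCRF-CEM cells (Homo sapiens) for inhibition, read by sulforhodamine B assay, with a stated time of 48 h, tested at 10 uM; on this read-out lower numbers stand for less inhibition and higher numbers for more inhibition at the one concentration tested (going by the name of the read-out). Compound 1 `O=Cc1ccc(-c2cn3ccnc3c(-c3ccc4ncn(C5CCCCC5)c4c3)n2)cc1` gives 77.9%. Compound 2 `Clc1ccc(-c2cn3ccnc3c(-c3ccc4ncn(C5CCCCC5)c4c3)n2)cc1` gives 11.4%, and compound 3 `COc1ccccc1-c1cn2ccnc2c(-c2ccc3ncn(C4CCCCC4)c3c2)n1` gives 17.4%. Compound 3 therefore stands second of the three numbers, within the scatter of compound 2 and far from compound 1: the step of a number 60.5 percentage points lower from compound 1 to compound 3 (beyond the scatter) is large, as is a number 66.5 percentage points lower from compound 1 to compound 2 (beyond the scatter), whereas a number 6 percentage points higher from compound 2 to compound 3 (within the scatter) lies within the scatter.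

Compound 4 `FC(F)(F)c1cccc(-c2cn3ccnc3c(-c3ccc4ncn(C5CCCCC5)c4c3)n2)c1` is not yet measured. Its change from compound 3 is 3-(trifluoromethyl)phenyl in place of 2-methoxyphenyl on an aromatic carbon. Within the data shown here, the steps that bear on it are those that exchange the aryl group on an aromatic carbon of the core: both the 4-formylphenyl compound 1 and the 4-chlorophenyl compound 2 have been set against compound 3, and only the formyl compound stands high. Among the measured compounds shown here, no measured compound carries a trifluoromethyl group, so the expectation rests on compound 2 and compound 3, and no step beyond the scatter is expected in this assay. Compound 4 is estimated at 16%, with a range from 2% to 40%. The expected step is a number 1.4 percentage points lower from compound 3 to compound 4 (within the scatter).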

Compound 4, a percentage reported as inhibition, at one concentration (the size of the read-out at that concentration, not a potency): 27.3%
The estimate for compound 4 lay 11.3 percentage points below the measured number; the range from low to high includes it.
By their numbers in this assay, from the lowest: compounds 2, 3 and 4 (each within the scatter of the next, the first and the last beyond it); then compound 1.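

In this assay, among these compounds, a third aryl group without a formyl substituent on this aromatic carbon stays far from the 4-formylphenyl compound (a number 50.6 percentage points lower from compound 1 to compound 4 (beyond the scatter)), so compound 1 remains the only high number among the four compounds. Among the compounds shown here, the 3-(trifluoromethyl)phenyl group is not separated from the 2-methoxyphenyl group (a number 9.9 percentage points higher from compound 3 to compound 4 (within the scatter)), yet it gives the first step beyond the scatter among the low compounds (a number 15.9 percentage points higher from compound 2 to compound 4 (beyond the scatter)), a modest one. Nothing measured here gives a reason for any of these steps.

Still open, on these data alone, is what a carboxylic acid, a hydroxymethyl group or an amine in place of the formyl group would give on the same phenyl ring. Also open, as far as these compounds go, is whether the gap between compound 2 and compound 4 follows the group itself or its place on the phenyl ring, as the two compounds differ in both.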